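Dropping a methoxy group: from compound 1 to compound 3

The source may report more compounds than this note shows. Statements on the series, on what has been measured and on what is new or still open speak of the compounds shown alone.

Measured so far in an ADME assay on 184B5 cells (Homo sapiens) for cytotoxicity, read by MTT assay, with a stated time of 72 h; a lower number here means a stronger inhibitor of growth, a higher number a weaker inhibitor of growth:
compound 1, `COc1ccc(OC(=O)Nc2ccc([Se]C#N)cc2)cc1`, gives 4500 nM
compound 2, `N#C[Se]c1ccc(NC(=O)OCc2ccc([N+](=O)[O-])cc2)cc1`, gives 6000 nM

Of the compounds shown here, two have been measured in this assay. Compound 1 shows the lower of the two numbers, but its nearest neighbour, compound 2, sits within the usual scatter of the assay, so the two cannot be ranked against each other; compound 1 and compound 2 are best read as one and the same level of growth inhibition. For the measured compounds named here, no pair of measured compounds differs in a single place, so no measured step is available.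

The next compound, compound 3, `N#C[Se]c1ccc(NC(=O)Oc2ccccc2)cc1`, follows from compound 1 by a single change: hydrogen in place of methoxy on an aromatic carbon. Nothing measured here tells how that change acts in this assay. Going by the values given here, with the only two numbers so far lying close together and no measured step to lean on, a step from compound 1 to compound 3 of size a 1.2-fold higher number from compound 1 to compound 3 (0.09 log units; within the scatter) is expected, that is, none that clearly passes beyond the scatter. Compound 3 is accordingly estimated at 5500 nM, within a range of 2500 nM to 12000 nM.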

Compound 3, concentration for 50% growth inhibition: 400 nM
For compound 3 the middle estimate is 14-fold (1.14 log units) above the measured one, outside the stated range (below it).
By their numbers in this assay, from the lowest: compound 3; then compounds 1 and 2 (each within the scatter of the next).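

In this assay, the aromatic carbon para to a large group proves sensitive to substitution: hydrogen in place of methoxy gives an 11-fold lower number from compound 1 to compound 3 (1.05 log units; beyond the scatter). For the compounds shown here, this is the first single-place change, and it shows that with the rest of compound 1 unchanged, the loss of the methoxy group alone is enough to make compound 3 a clearly stronger inhibitor of growth. No measurement shown here speaks to what lies behind this step.

Only one replacement at this place is in view, so the compounds shown leave open whether any departure from methoxy would have the same result or whether the outcome is particular to hydrogen. It also remains unsettled whether a fluorine atom, a methyl group, an amine or a longer ethoxy chain at the same place would leave the number close to that of compound 1, close to that of compound 3, or somewhere between the two.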